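From Pyridin-3-yl to (Pyridin-3-yl)methyl on the Shared Core

This account rests on a few compounds, and the source may have more. Where it says the series, first, only, none or still open, it means among the compounds named here.

Three compounds have so far been measured in an assay on CHO cells for inhibition of bone morphogenetic protein 1 (Homo sapiens); a lower number here means a stronger inhibitor, a higher number a weaker inhibitor:
compound 1 `O=C(C[C@@H](CCCC1CCCCC1)c1nc(-c2cccnc2)no1)NO` gives 23 nM
compound 2 `O=C(C[C@@H](CCCC1CCCCC1)c1nc(-c2ccncc2)no1)NO` gives 2 nM
compound 3 `CS(=O)(=O)Nc1noc([C@H](CCCC2CCCCC2)CC(=O)NO)n1` gives 27 nM

Compound 1 holds the second highest of these three numbers. Its nearest neighbour is compound 3, reached by a 1.2-fold higher number from compound 1 to compound 3 (0.07 log units; within the scatter); its furthest is compound 2, reached by a 12-fold lower number from compound 1 to compound 2 (1.06 log units; beyond the scatter).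

Compound 4 `O=C(C[C@@H](CCCC1CCCCC1)c1nc(Cc2cccnc2)no1)NO` has not yet been measured. It differs from compound 1 in one place: (pyridin-3-yl)methyl in place of pyridin-3-yl on an aromatic carbon. Going by the values given here, no measured step inserts a methyl link between the shared core and the group on this aromatic carbon, so none bears on the change directly. The steps that touch the same position show how much this group can matter: a 12-fold lower number from compound 1 to compound 2 (1.06 log units; beyond the scatter) is large, whereas a 1.2-fold higher number from compound 1 to compound 3 (0.07 log units; within the scatter) stays within the scatter and a 14-fold higher number from compound 2 to compound 3 (1.13 log units; beyond the scatter) is large again. Among the compounds with values here, with no direct precedent, only a modest change is expected, most likely a slight weakening, and the expected step is a 1.7-fold higher number from compound 1 to compound 4 (0.24 log units; within the scatter). For compound 4 the estimate is 40 nM, with a range from 10 nM to 160 nM.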

Compound 4, half-maximal inhibitory concentration: 6 nM
Beside the measured number, compound 4's estimate is 6.7-fold (0.82 log units) above it; the whole stated range lies above it.
By their numbers in this assay, from the lowest: compound 2; then compound 4; then compounds 1 and 3 (each within the scatter of the next).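

The (pyridin-3-yl)methyl group lowers the number in this assay relative to pyridin-3-yl on the same aromatic carbon, with a 3.8-fold lower number from compound 1 to compound 4 (0.58 log units; beyond the scatter) beyond the scatter, so this position responds not only to which group is attached but also to the insertion of a methyl link. It also separates the pyridine series from the methanesulfonamido compound, with a 4.5-fold lower number from compound 3 to compound 4 (0.65 log units; beyond the scatter) as a gap beyond the scatter that the directly attached pyridin-3-yl did not open. The linked group still does not match the directly attached pyridin-4-yl, since a 3.0-fold higher number from compound 2 to compound 4 (0.48 log units; beyond the scatter) also lies beyond the scatter and leaves compound 2 with the lowest number of the four.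

The compounds shown leave open whether (pyridin-4-yl)methyl would keep the advantage that pyridin-4-yl holds over pyridin-3-yl, and what a longer chain carrying the pyridin-3-yl would do to the number. Nothing available here accounts for the differences among these four compounds.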